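Permeability notes on a benzimidazole-ether acid pair and one new analogue

The source may hold more compounds than are shown below. What is called first, only, known or untested is meant among the compounds shown, and "the series" means these compounds.

Measured so far in an ADME assay for permeability, using PAMPA, with a stated time of 4 h; on this read-out lower numbers stand for lower permeability and higher numbers for higher permeability:
compound 1, `Cn1c(COc2cccc(C(=O)O)c2)nc2cnc(Oc3ccc(Cl)c(F)c3)cc21`: 11.2 10^-6 cm/s
compound 2, `Cc1ccnc(Oc2ccc3nc(COc4cccc(C(=O)O)c4)n(C)c3c2)c1`: 3.5 10^-6 cm/s

Compound 2 gives the lower of the two numbers, and the gap to compound 1 lies beyond the usual scatter of this assay. Going by the values given here, no single-point step between measured compounds is available.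

The next compound, compound 3, `Cc1cc(Cl)cnc1Oc1ccc2nc(COc3cccc(C(=O)O)c3)n(C)c2c1`, differs from compound 2 in one place: 5-chloro-3-methylpyridin-2-yl in place of 4-methylpyridin-2-yl on an oxygen on an aromatic ring. Among the compounds with values here, with no measured step of this kind to lean on, the change is expected to give a modest rise, a 1.7-fold higher number from compound 2 to compound 3 (0.23 log units; within the scatter), though a result within the scatter is also plausible. Compound 3 is estimated at 6 10^-6 cm/s, with a range from 3 10^-6 cm/s to 12 10^-6 cm/s.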

Compound 3, apparent permeability: 13.7 10^-6 cm/s
Compound 3: middle estimate off by 2.3-fold (0.36 log units), on the low side, and the stated range ends below it.
By their numbers in this assay, from the lowest: compound 2; then compounds 1 and 3 (each within the scatter of the next).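

In this assay, the group on the oxygen on an aromatic ring proves able to move the read-out beyond the scatter: 5-chloro-3-methylpyridin-2-yl in place of 4-methylpyridin-2-yl gives a 3.9-fold higher number from compound 2 to compound 3 (0.59 log units; beyond the scatter) in this series. Going by these compounds alone, this is the first change at a single place that can be read here. No measurement shown accounts for the size of this step.

The step swaps a whole group, so the shares of the chlorine and the methyl remain unseparated. Open too, going by these compounds, is how 3-methylpyridin-2-yl or 5-chloropyridin-2-yl alone would read, and how an amide in place of the carboxylic acid would read.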